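The compounds below may be only part of what the source reports. "The series", "measured", "known", "first", "only" and "open" are said of these compounds alone.

Measured compounds in an assay on HEK293 cells for agonist activity at Toll-like receptor 2 (Homo sapiens); a lower number here means that less compound is needed, a higher number that more compound is needed for the effect:
compound 1 `CCCCCCCCCCCC(=O)OC[C@H](CSC[C@@H](N)C(=O)NCCO)OC(=O)CCCCCCCCCCC`, 24 nM
compound 2 `CCCCCCCCCCCC(=O)OC[C@H](CSC[C@@H](N)C(=O)NCCOCCOS(=O)(=O)O)OC(=O)CCCCCCCCCCC`, 61 nM
compound 3 `CCCCCCCCCCCC(=O)OC[C@H](CSC[C@@H](N)C(=O)NCCCCCC(=O)O)OC(=O)CCCCCCCCCCC`, 108 nM

Compound 1 gives the lowest number of the three; the nearest is compound 2, a 2.5-fold higher number from compound 1 to compound 2 (0.41 log units; beyond the scatter), and the furthest compound 3, a 4.5-fold higher number from compound 1 to compound 3 (0.65 log units; beyond the scatter). On these data alone, compound 4 `CCCCCCCCCCCC(=O)OC[C@H](CSC[C@@H](N)C(=O)NCCCN)OC(=O)CCCCCCCCCCC` is untested; it differs from compound 1 by aminomethyl in place of hydroxy on a saturated chain carbon, two bonds along the chain from an amide-type nitrogen. Both measured steps from compound 1 alter the same hydroxy and both raise the number by modest amounts; between compound 2 and compound 3 the step is a 1.8-fold higher number from compound 2 to compound 3 (0.25 log units; within the scatter). The present change is smaller than either, so a smaller rise, or none beyond the scatter, is expected in this assay. Compound 4 is therefore estimated at 45 nM, range 15 nM to 140 nM, an expected step of a 1.9-fold higher number from compound 1 to compound 4 (0.27 log units; within the scatter).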

Compound 4, half-maximal effective concentration: 1960 nM
Compound 4: middle estimate off by 44-fold (1.64 log units), on the low side, outside the stated range (above it).
By their numbers in this assay, from the lowest: compound 1; then compounds 2 and 3 (each within the scatter of the next); then compound 4.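

Going by these compounds alone, replacing hydroxy with aminomethyl at this position, a small change by atom count, gives by far the largest step so far in this assay: an 82-fold higher number from compound 1 to compound 4 (1.91 log units; beyond the scatter). Much larger side-chain ends are far better accommodated than the terminal amine, as shown by a 32-fold higher number from compound 2 to compound 4 (1.51 log units; beyond the scatter) and an 18-fold higher number from compound 3 to compound 4 (1.26 log units; beyond the scatter). No available data bear on the origin of this large rise.

On these data alone, it remains open whether the rise follows the primary amine itself or the three-carbon chain carrying it. A terminal acetamide or dimethylamino group on the same chain could help separate these.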